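The source may hold more compounds than are shown below. What is called first, only, known or untested is meant among the compounds shown, and "the series" means these compounds.

Compound 1 `Cc1ccc(S(=O)(=O)NC(=O)Nc2ccccc2C(=O)/C=C/c2ccccc2)cc1` and compound 2 `COc1cccc(/C=C/C(=O)c2ccccc2NC(=O)NS(=O)(=O)c2ccc(C)cc2)c1` share one core. In an ADME assay on the whole organism for cytotoxicity, with Artemia salina as the target, with a stated time of 24 h (on this read-out higher numbers stand for an effect only at larger amounts of compound and lower numbers for an effect already at smaller amounts), compound 1 gives 25 ug/mL, and in this assay compound 2 gives 23.2 ug/mL; these two values lie within the scatter of each other. Among the measured compounds shown here, the only measured step, a 1.1-fold lower number from compound 1 to compound 2 (0.03 log units; within the scatter), adds a methoxy group and changes nothing beyond the scatter. Compound 3 `Cc1ccc(S(=O)(=O)NC(=O)Nc2ccccc2C(=O)/C=C/c2ccccc2O)cc1` carries 2-hydroxyphenyl in place of 3-methoxyphenyl on a double-bonded chain carbon bound to a double-bonded chain carbon. For the measured compounds named here, that single step is the only guide, and it points to no shift, so for compound 3 the expected step is a 1.0-fold higher number from compound 2 to compound 3 (0.01 log units; within the scatter), nothing beyond the scatter. Compound 3 is therefore estimated at 24 ug/mL, with a range from 12 ug/mL to 48 ug/mL.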

Compound 3, concentration for half-maximal effect: 32.3 ug/mL
Compound 3: the middle estimate sits 1.3-fold (0.13 log units) below what was measured; measured number inside the range.
By their numbers in this assay, from the lowest: compounds 2, 1 and 3 (each within the scatter of the next).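

In this assay, 2-hydroxyphenyl in place of 3-methoxyphenyl gives a 1.4-fold higher number from compound 2 to compound 3 (0.14 log units; within the scatter), and adding a hydroxy group gives a 1.3-fold higher number from compound 1 to compound 3 (0.11 log units; within the scatter). This place on the chain therefore holds a ring with a hydrogen-bond donor or one without, and all three compounds stay within the scatter of one another. No measured evidence here bears on these small differences. From the compounds shown here alone, whether an amine or a carboxylic acid on this ring would give a step beyond the scatter remains open. So does whether moving the hydroxy to another ring carbon would do so.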